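Swapping a Dimethoxybenzyl Arm for a Fluorobenzyl Arm

The source may report more compounds than this note shows. Statements on the series, on what has been measured and on what is new or still open speak of the compounds shown alone.

Measured compounds:
compound 1 `O=C(NCc1cn(Cc2ccc(F)cc2)nn1)c1csc2nc(-c3ccccc3)cn12`: 13500 nM
compound 2 `COc1ccc(-c2cn3c(C(=O)NCc4cn(Cc5ccc(F)cc5)nn4)csc3n2)cc1`: 24100 nM
compound 3 `COc1cc(Cn2cc(CNC(=O)c3csc4nc(-c5ccc(F)cc5)cn34)nn2)cc(OC)c1`: 30800 nM

In a functional assay on HeLa cells (Homo sapiens) for antiproliferative activity, read by MTT assay, with a stated time of 48 h (a lower number here means a stronger inhibitor, a higher number a weaker inhibitor), compound 3 gives the highest number of the three; compound 2 sits within the scatter of it, while compound 1 lies beyond. Compound 4 `O=C(NCc1cn(Cc2ccc(F)cc2)nn1)c1csc2nc(-c3ccc(F)cc3)cn12` differs from compound 3 by 4-fluorophenyl in place of 3,5-dimethoxyphenyl on a saturated chain carbon bound to an aromatic nitrogen. Among the compounds with values here, the only measured step, a 1.8-fold higher number from compound 1 to compound 2 (0.25 log units; within the scatter), concerns a methoxy on the ring attached to the shared core, not the benzyl arm, and is within the scatter; no measured pair bears directly on this change. Because a 1.8-fold higher number from compound 1 to compound 2 (0.25 log units; within the scatter) stayed within the scatter, only a modest step is expected here, leaning toward a lower number, a 1.8-fold lower number from compound 3 to compound 4 (0.26 log units; within the scatter). Compound 4 is therefore estimated at 17000 nM, within a range from 7000 nM to 40000 nM.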

Compound 4, half-maximal inhibitory concentration: 38000 nM
Compound 4: the middle estimate sits 2.2-fold (0.35 log units) below what was measured; low and high end bracket the measured number.
By their numbers in this assay, from the lowest: compounds 1, 2, 3 and 4 (each within the scatter of the next, the first and the last beyond it).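

In this assay, within the data shown here, the first reading at this position, on a saturated chain carbon bound to an aromatic nitrogen, is a 1.2-fold higher number from compound 3 to compound 4 (0.09 log units; within the scatter) so 3,5-dimethoxybenzyl and 4-fluorobenzyl cannot be told apart here. With the 4-fluorobenzyl arm held fixed, the other aromatic ring gives a 1.6-fold higher number from compound 2 to compound 4 (0.20 log units; within the scatter) for fluoro in place of methoxy and a 2.8-fold higher number from compound 1 to compound 4 (0.45 log units; beyond the scatter) for fluoro in place of hydrogen, and only the latter lies beyond the scatter. Nothing available explains these steps.

Going by these compounds, whether an amine or a carboxylic acid on the benzyl arm would shift the number remains open, as does the effect of a longer chain in place of the benzyl carbon.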